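A few compounds are considered here, and "the series" means these few. Any claim that something is new, unique, unknown or untested is made for them only; others in the source may bear on it.

Compound 1 `CCCSc1nc(N/N=C/c2ccccc2F)c2nnn(Cc3ccccc3)c2n1`: > 64000 nM (a limit)
Compound 2 `CCCSc1nc(N/N=C(\C)c2ccccc2O)c2nnn(Cc3ccco3)c2n1`: 4760 nM

Within the data shown here, in a functional assay on MGC-803 cells (Homo sapiens) for antiproliferative activity, read by MTT assay, with a stated time of 72 h (a higher number here means a weaker inhibitor, a lower number a stronger inhibitor), compound 2 gives 4760 nM, the only actual number in this pair. For compound 1 the entry > 64000 nM is a limit of this assay rather than a number, as the limit of > 64000 nM in this assay, at which 1 of the 2 values shown sits, records. Among the measured compounds shown here, compound 3 `CCCSc1nc(N/N=C(\C)c2ccccc2O)c2nnn(Cc3ccccc3Cl)c2n1` differs from compound 2 by 2-chlorophenyl in place of furan-2-yl on a saturated chain carbon bound to an aromatic nitrogen, a change for which no measured step exists here. The expected step of a 1.4-fold higher number from compound 2 to compound 3 (0.14 log units; within the scatter) in this assay is therefore small, probably not beyond the scatter, with a slight lean toward weaker inhibition. Compound 3 is estimated at 6500 nM, with a range from 2000 nM to 25000 nM.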

Compound 3, half-maximal inhibitory concentration: 35000 nM
Compound 3: middle estimate off by 5.4-fold (0.73 log units), on the low side, and the stated range ends below it.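

Among these compounds, the change from (furan-2-yl)methyl to 2-chlorobenzyl is the first single-place comparison, and in this assay it gives a 7.4-fold higher number from compound 2 to compound 3 (0.87 log units; beyond the scatter). The group on the saturated chain carbon bound to an aromatic nitrogen therefore matters for this read-out: with the rest of compound 2 unchanged, this exchange alone shifts the series toward weaker inhibition. Nothing shown gives a cause for this step.

One step cannot separate the contribution of the chlorine from that of the ring exchange. From the compounds shown here alone, whether a thiophen-2-yl ring or a longer chain at this place would track compound 2 or compound 3 remains open.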